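The source may report more compounds than this note shows. Statements on the series, on what has been measured and on what is new or still open speak of the compounds shown alone.

Going by the values given here, in a functional assay on HT-29 cells (Homo sapiens) for antiproliferative activity, read by MTT assay, with a stated time of 72 h (a lower number here means a stronger inhibitor, a higher number a weaker inhibitor), two compounds sharing one core have numbers so far. Compound 1 `Nc1nc(N)c2cc(CSC(=S)N3CCN(c4ccccc4)CC3)ccc2n1` gives 2760 nM, and compound 2 `Nc1nc(N)c2cc(CSC(=S)N3CCN(c4ccc(Cl)cc4)CC3)ccc2n1` gives 7480 nM, the higher of the two and so the weaker inhibitor. The next molecule, compound 3 `Nc1nc(N)c2cc(CSC(=S)N3CCN(c4ccccc4Cl)CC3)ccc2n1`, has the same atoms as compound 2, joined differently: 2-chlorophenyl in place of 4-chlorophenyl on an amine nitrogen in a ring. In words, 2-chlorophenyl takes the place of 4-chlorophenyl on an amine nitrogen in a ring.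

Among the compounds with values here, only one measured step bears on this change. Putting chloro in place of hydrogen on an aromatic carbon gave a 2.7-fold higher number from compound 1 to compound 2 (0.43 log units; beyond the scatter), a modest step beyond the usual scatter. Within the data shown here, that step compares a chloro group with hydrogen, and no measured pair shows what moving the chloro does. Compound 3 keeps its chloro group, so the step offers only a loose guide, and no change beyond the scatter is expected in this assay, with a slight lean toward a lower number. The expected change is a 1.5-fold lower number from compound 2 to compound 3 (0.17 log units; within the scatter). For compound 3 the estimated value is 5000 nM, with an expected range from 2000 nM to 12000 nM.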

Compound 3, half-maximal inhibitory concentration: 3900 nM
For compound 3 the middle estimate is 1.3-fold (0.11 log units) above the measured one; the range from low to high includes it.
By their numbers in this assay, from the lowest: compounds 1, 3 and 2 (each within the scatter of the next, the first and the last beyond it).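

In this assay, moving the chloro group from 4-chlorophenyl to 2-chlorophenyl gives a 1.9-fold lower number from compound 2 to compound 3 (0.28 log units; within the scatter), so this first direct test of where the chloro group sits shows no change that can be told apart from the ordinary variation between repeat measurements. The earlier chloro step also looks less general now: with the chloro group as 2-chlorophenyl, replacing hydrogen gives a 1.4-fold higher number from compound 1 to compound 3 (0.15 log units; within the scatter), which is within the scatter, whereas with the chloro group as 4-chlorophenyl it gave a 2.7-fold higher number from compound 1 to compound 2 (0.43 log units; beyond the scatter), which is beyond it, even though the two chloro compounds themselves cannot be separated. No measurement offered here explains how the chloro group acts at either place.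

The compounds shown leave open whether a group other than chloro, such as fluoro or methoxy, would give the same small differences at these two places on the phenyl ring. They also leave open what happens if the whole phenyl ring on the amine nitrogen gives way to a simple methyl group or a longer carbon chain.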